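From 3-methoxyphenyl to 6-methoxypyridin-3-yl in compound 1

This account rests on a few compounds, and the source may have more. Where it says the series, first, only, none or still open, it means among the compounds named here.

- Compound 1 `C/C=C/C(=O)Nc1cccc(Oc2nc(Nc3cccc(OC)c3)nc3c2CSCC3)c1`: 13800 nM
- Compound 2 `COc1cccc(Nc2nc3c(c(Oc4cccc(NC(=O)/C=C/C(C)C)c4)n2)CSCC3)c1`: > 50000 nM (a limit)

Among the compounds with values here, in a functional assay on HeLa cells (Homo sapiens) for antiproliferative activity, read by MTT assay, with a stated time of 72 h (on this read-out lower numbers stand for stronger inhibition and higher numbers for weaker inhibition), compound 1 gives 13800 nM, the only actual number so far. Compound 2 gives > 50000 nM, which is a limit. Compound 3 `C/C=C/C(=O)Nc1cccc(Oc2nc(Nc3ccc(OC)nc3)nc3c2CSCC3)c1` carries 6-methoxypyridin-3-yl in place of 3-methoxyphenyl on a nitrogen on an aromatic ring. Within the data shown here, the only measured step, an at least 3.6-fold higher number from compound 1 to compound 2 (0.55 log units; beyond the scatter), puts isopropyl in place of methyl on the chain and leaves this place untouched. It therefore sets no size here, and no step beyond the scatter is expected in this assay. The expected step is a 1.0-fold higher number from compound 1 to compound 3 (0.01 log units; within the scatter). Compound 3 is estimated at 14000 nM, within a range of 5000 nM to 40000 nM.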

Compound 3, half-maximal inhibitory concentration: 16500 nM
Compound 3: the middle estimate sits 1.2-fold (0.07 log units) below what was measured; low and high end bracket the measured number.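

In this assay, within the data shown here, the step of a 1.2-fold higher number from compound 1 to compound 3 (0.08 log units; within the scatter) is the first reading at this place, on a nitrogen on an aromatic ring, as the earlier step concerned only the chain. Exchanging 3-methoxyphenyl for 6-methoxypyridin-3-yl, with its ring nitrogen, leaves the two values within the scatter of each other, so this exchange is tolerated here. Nothing shown gives a cause for this result.

As far as these compounds go, it remains open whether an amine or a carboxylic acid in place of the methoxy group would be tolerated equally. A single exchange also cannot show how far this tolerance extends at this place.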